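The source may hold more compounds than are shown below. What is called first, only, known or untested is meant among the compounds shown, and "the series" means these compounds.

Compound 1 `COc1nc(-c2ccc(Br)cc2)ccc1[C@@H](c1ccccc1)[C@@](O)(CCN(C)C)c1cccc2ccccc12` was tested in a toxicity assay on Vero cells (Chlorocebus sabaeus) for cytotoxicity (a higher number here means that more compound is tolerated, a lower number that less compound is tolerated), where it gives > 50 ug/mL, a limit of the assay rather than a number. Compound 2 `COc1ncc(-c2ccccc2)cc1[C@@H](c1ccccc1)[C@@](O)(CCN(C)C)c1cc(F)ccc1F` in this assay likewise gives only the limit > 50 ug/mL. Compound 3 `COc1ncc(-c2ccccc2)cc1[C@@H](c1ccccc1)[C@@](O)(CCN(C)C)c1cccc2ccccc12` in this assay also stops at the limit > 50 ug/mL. The step that the two limits leave unreadable from compound 2 to compound 3 is therefore unreadable, as the limit of > 50 ug/mL in this assay, at which 3 of the 3 values shown sit, shows. Compound 4 `COc1nc(-c2ccc(C#N)cc2)ccc1[C@@H](c1ccccc1)[C@@](O)(CCN(C)C)c1cccc2ccccc12` differs from compound 1 by cyano in place of bromo on an aromatic carbon. Within the data shown here, no measured step covers this change, and the one measured step is unreadable, so in this assay no shift beyond the scatter is expected. Compound 4 is expected to give about 50 ug/mL in this assay, within 25 ug/mL to 100 ug/mL, most likely again only a limit. The expected step of a number no higher from compound 1 to compound 4 (the limit leaves the size open) is then essentially none.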

Compound 4, half-maximal cytotoxic concentration: > 50 ug/mL
Compound 4 gave a limit, no number; the forecaster's own chance of this, stated with the estimate: 80%; the middle value lies on the limit itself.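

Compound 1 and compound 4 both stop at a limit, so no step between them can be read: the limit of > 50 ug/mL in this assay, at which 4 of the 4 values shown sit.

The compounds shown leave open what number any of them would give in this assay, and whether cyano in place of bromo shifts it at all.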